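The source may report more compounds than this note shows. Statements on the series, on what has been measured and on what is new or still open speak of the compounds shown alone.

Measured so far:
compound 1 `O=C(O)c1cnc2c(F)cccc2c1O` — > 100 mg/kg
compound 2 `O=c1c(-c2nn[nH]n2)c[nH]c2c(C(F)(F)F)cccc12` — > 25 mg/kg
compound 3 `COc1ccc(OC)c2c(=O)c(-c3nn[nH]n3)c[nH]c12` — > 10 mg/kg

In a functional assay on the whole organism (strain Sprague-Dawley) for inhibition, with Rattus norvegicus as the target (on this read-out lower numbers stand for an effect already at smaller amounts and higher numbers for an effect only at larger amounts of compound), compound 1 gives > 100 mg/kg, which is a limit of the assay and not a number. Compound 2 gives > 25 mg/kg in this assay, again a limit. Compound 3 gives > 10 mg/kg in this assay, also a limit. Compound 3 thus stands at a limit only (the limit of > 10 mg/kg in this assay, at which 1 of the 3 values shown sits); the two other values shown are limits as well the limit of > 100 mg/kg in this assay, at which 1 of the 3 values shown sits (the limit of > 25 mg/kg in this assay, at which 1 of the 3 values shown sits), so no ordering among the three can be drawn.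

Compound 4 `COc1cccc2c(=O)c(-c3nn[nH]n3)c[nH]c12` is not yet measured in this assay. It differs from compound 3 in one place: hydrogen in place of methoxy on an aromatic carbon. For the measured compounds named here, no step between measured compounds is available to weigh this change against. With three limits and no number to anchor a direction, the expected step that the limit leaves unreadable from compound 3 to compound 4 is none beyond the usual scatter. Compound 4 is therefore estimated at 30 mg/kg in this assay, with a range from 10 mg/kg to 100 mg/kg, and most likely only a limit will be reported.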

Compound 4, minimum effective dose: 0.312 mg/kg
Compound 4: the middle estimate sits 96-fold (1.98 log units) above what was measured; measured number below the stated range.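

In this assay hydrogen in place of methoxy on an aromatic carbon para to a methoxy group gives an at least 32-fold lower number from compound 3 to compound 4 (1.50 log units; beyond the scatter) and so shows that this position strongly affects the read-out, which the three limits alone could not show. Methoxy in place of trifluoromethyl on an aromatic carbon gives an at least 80-fold lower number from compound 2 to compound 4 (1.90 log units; beyond the scatter), so the group that remains on the ring of compound 4 also matters, and only this combination of substituents shown reaches a measured number. No measurement shown bears on why these numbers fall.

Whether the remaining methoxy is needed at all stays open, as the core with hydrogen at both places is not among the compounds shown. Equally open, going by these compounds, is how an ethoxy group or an amine would behave in place of that methoxy.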